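Shortening the ring-nitrogen substituent of compound 1

A few compounds are considered here, and "the series" means these few. Any claim that something is new, unique, unknown or untested is made for them only; others in the source may bear on it.

Compound 1 `CC(C)n1c(=O)n(C(=O)NCCN2CCN(C)CC2)c2ccccc21` is assessed in a functional assay for antagonist activity at 5-hydroxytryptamine receptor 4 (Cavia porcellus); a higher number here means a more potent compound, by a factor of ten per unit of this negative logarithm, a lower number a less potent compound; in this assay compound 1 gives < 6, which is a limit of the assay and not a number. Compound 2 `CC(C)n1c(=O)n(C(=O)NCCN2CCN(C)CC2)c2cc(Cl)ccc21` likewise gives < 6, again only a limit. The step that the two limits leave unreadable from compound 1 to compound 2 stays unreadable because of the limit of < 6 in this assay, at which 2 of the 2 values shown sit. Compound 3 `CN1CCN(CCNC(=O)n2c(=O)n(C)c3ccccc32)CC1` carries methyl in place of isopropyl on an aromatic nitrogen. For the measured compounds named here, no measured step touches this position, so the expectation rests solely on where compound 1 sits. For compound 3 a step that the limit leaves unreadable from compound 1 to compound 3 is expected, within the scatter. Compound 3 is therefore estimated at 5.5, range 4.5 to 6.4, with a limit read-out again the most likely outcome.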

Compound 3, negative logarithm of the antagonist equilibrium constant: < 6
Compound 3 gave a limit, no number; the forecaster's own chance of this, stated with the estimate: 70%; the middle value lies beyond the limit too.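

No step can be read between compound 1 and compound 3, because both results are limits of the assay and not numbers: the limit of < 6 in this assay, at which 3 of the 3 values shown sit. The compounds shown leave open whether methyl in place of isopropyl, or chloro in place of hydrogen, changes the read-out in this assay at all.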